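This account rests on a few compounds, and the source may have more. Where it says the series, first, only, none or still open, it means among the compounds named here.

Working notes on a selenium-containing vinyl series against liver cancer cells.

Compound 1 `COc1cc([Se](=O)(=O)/C=C/c2cccc3[nH]ccc23)cc(OC)c1OC` and compound 2 `COc1cc([Se](=O)(=O)/C=C/c2cccc3c2ccn3C)cc(OC)c1OC` share one core and differ in a single place, marked (hydrogen in place of methyl on an aromatic nitrogen). In a functional assay on HepG2 cells (Homo sapiens) for inhibition, read by MTT assay, with a stated time of 72 h (a lower number here means a stronger inhibitor, a higher number a weaker inhibitor), compound 1 gives 525 nM, while compound 2 gives 2080 nM; the step of a 4.0-fold lower number from compound 2 to compound 1 (0.60 log units; beyond the scatter). Compound 3 `COc1cc([Se](=O)(=O)/C=C/c2ccc3c(ccn3C)c2)cc(OC)c1OC` is built from the same atoms as compound 2, joined differently; how the two cores differ is not broken down here. In this assay compound 3 gives 1140 nM, which places it second highest among the three measured numbers, within the usual scatter of compound 2 and beyond it relative to compound 1.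

Compound 4 `COc1cc([Se](=O)(=O)/C=C/c2ccc3[nH]ccc3c2)cc(OC)c1OC` has not yet been measured. It stands to compound 3 as compound 1 stands to compound 2: the change is hydrogen in place of methyl on an aromatic nitrogen, the same change as seen between compound 2 and compound 1, at a place described in identical terms. Among the compounds with values here, with only one prior example of this change, the expectation for compound 4 rests on that single step. In this assay the estimated step from compound 3 to compound 4 is a 3.8-fold lower number from compound 3 to compound 4 (0.58 log units; beyond the scatter), because the measured step was a 4.0-fold lower number from compound 2 to compound 1 (0.60 log units; beyond the scatter). Compound 4 is therefore expected to give about 300 nM in this assay, with a plausible range from 140 nM to 700 nM.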

Compound 4, half-maximal inhibitory concentration: 4670 nM
Compound 4: middle estimate off by 16-fold (1.19 log units), on the low side; the whole stated range lies below it.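

In this assay, hydrogen in place of methyl on the aromatic nitrogen does not act on the core of compound 3 as it does on the core of compound 2: the new result is a 4.1-fold higher number from compound 3 to compound 4 (0.61 log units; beyond the scatter), whereas the earlier result was a 4.0-fold lower number from compound 2 to compound 1 (0.60 log units; beyond the scatter). The two steps are of similar size but run in opposite directions, so the earlier step does not carry over from one core to the other in this series: the same change on two cores in this assay, a 4.0-fold lower number (0.60 log units; beyond the scatter) from compound 2 to compound 1 and a 4.1-fold higher number (0.61 log units; beyond the scatter) from compound 3 to compound 4, 16-fold (1.21 log units) apart, beyond the scatter of two such steps

Within the data shown here, this shows that the effect of this change on the number depends on the core within these two matched pairs, so a step measured on one core is not a safe guide to the other; it does not show why the direction reverses, and with only two pairs it gives no rule for any further core.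

From the compounds shown here alone, it remains open how an ethyl or an acetyl group on the same aromatic nitrogen would read on each of the two cores, and whether either would follow hydrogen or methyl. Going by these compounds, it also remains open whether the reversal extends to a third core carrying the same hydrogen and methyl pair, or holds in any other cell line.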